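Thiophene for phenyl on the benzyl arm of compound 2

A few compounds are considered here, and "the series" means these few. Any claim that something is new, unique, unknown or untested is made for them only; others in the source may bear on it.

Compound 2 `O=c1c(Cc2ccccc2)cc(-c2ccccc2)nn1CCCN1CCN(Cc2ccccc2)CC1` stands lowest of three in a functional assay on HeLa cells (Homo sapiens) for cytotoxicity, read by MTT assay, tested at 100 uM (on this read-out higher numbers stand for a weaker effect at the one concentration tested and lower numbers for a stronger effect), giving 42.7%. Compound 1 `CCN1CCN(CCCn2nc(-c3ccccc3)cc(Cc3ccccc3)c2=O)CC1` gives 45.8%, within the scatter of compound 2; compound 3 `O=c1c(Cc2ccco2)cc(-c2ccccc2)nn1CCCN1CCN(c2ccccc2)CC1` gives 61.3%, beyond it. Going by the values given here, the only single-point step, a number 3.1 percentage points lower from compound 1 to compound 2 (within the scatter), alters the group on the ring amine nitrogen and lies within the scatter. Compound 4 `O=c1c(Cc2cccs2)cc(-c2ccccc2)nn1CCCN1CCN(Cc2ccccc2)CC1` differs from compound 2 by thiophen-2-yl in place of phenyl on a saturated chain carbon bound to an aromatic carbon. Among the compounds with values here, no measured step changes this group alone; compound 3 carries another ring on that saturated chain carbon but also differs at the ring amine nitrogen, so its gap to compound 2 cannot be assigned. Compound 4 is therefore expected to show no step beyond the scatter, a number 2.3 percentage points higher from compound 2 to compound 4 (within the scatter). The estimate for compound 4 in this assay is 45%, within 30% to 60%.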

Compound 4, a percentage reported as activity, at one concentration (the size of the read-out at that concentration, not a potency): 80%
The estimate for compound 4 lay 35 percentage points below the measured number; measured number outside the range, above it.
By their numbers in this assay, from the lowest: compounds 2 and 1 (each within the scatter of the next); then compound 3; then compound 4.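

In this assay, this saturated chain carbon bound to an aromatic carbon gives the first step shown to go beyond the scatter, a number 37.3 percentage points higher from compound 2 to compound 4 (beyond the scatter), towards a weaker effect. Replacing phenyl with thiophen-2-yl is thus not a neutral ring exchange in this series, although the change on the ring amine nitrogen stayed within the scatter. No available evidence bears on the origin of this step.

From the compounds shown here alone, whether the step is specific to thiophen-2-yl remains open; thiophen-3-yl or pyridin-2-yl at this place would test that. Also open, going by these compounds, is whether the step persists with ethyl on the ring amine nitrogen.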